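The compounds below may be only part of what the source reports. "The series", "measured", "known", "first", "only" and "open" are said of these compounds alone.

Measured so far:
- compound 1, `CCC[C@@H]1NC(=O)[C@@H](C(C)C)NC(=O)[C@@H](Cc2ccccc2)NCCOc2ccccc2CCCNC1=O`: 57 nM
- compound 2, `CCC[C@@H]1NC(=O)[C@@H](C(C)C)NC(=O)[C@@H](CC2CCCCC2)NCCOc2ccccc2CCCNC1=O`: 3250 nM

In an assay on isolated protein for displacement of a labelled ligand from Motilin receptor (Homo sapiens) (on this read-out lower numbers stand for stronger inhibition and higher numbers for weaker inhibition), compound 2 stands highest of the two numbers; its nearest neighbour is compound 1, and a 57-fold higher number from compound 1 to compound 2 (1.76 log units; beyond the scatter) separates them, a step brought about by cyclohexyl in place of phenyl on a saturated chain carbon bound to a saturated ring carbon had it been run the other way, namely the exchange of a six-membered aromatic ring for a six-membered saturated ring on the same saturated chain carbon.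

Compound 3, `CCC[C@@H]1NC(=O)[C@@H](C(C)C)NC(=O)[C@@H](c2ccccc2)NCCOc2ccccc2CCCNC1=O`, is not yet measured. It differs from compound 2 by phenyl in place of cyclohexylmethyl on a saturated ring carbon. For the measured compounds named here, this change brings the aromatic ring back, as in compound 1, but without the chain carbon that compound 1 carries; no measured step covers that shortening. Going by the values given here, the only step that bears on it is a 57-fold higher number from compound 1 to compound 2 (1.76 log units; beyond the scatter), and its reversal argues for a large fall. The estimate for compound 3 is therefore 120 nM (range 25 nM to 700 nM), which means an expected step of a 27-fold lower number from compound 2 to compound 3 (1.43 log units; beyond the scatter), in the direction of compound 1 rather than beyond it, with added width for the untested loss of the chain carbon.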

Compound 3, inhibition constant: > 10000 nM
Compound 3 was reported as a limit; the forecaster's own chance of this, stated with the estimate: 5%; middle value at least 83-fold (1.92 log units) from the limit.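

In this assay compound 3 gives > 10000 nM, which is a limit of the assay and not a number. On the saturated ring carbon next to the ring nitrogen, the aromatic ring alone does not keep the read-out of the benzyl compound, since phenyl in place of benzyl gives an at least 170-fold higher number from compound 1 to compound 3 (2.24 log units; beyond the scatter). The cyclohexylmethyl group, with its saturated ring on a chain carbon, also does better here than phenyl with no chain carbon, as shown by an at least 3.0-fold higher number from compound 2 to compound 3 (0.48 log units; beyond the scatter), so the chain carbon matters for this position as well as the type of ring.

How far compound 3 lies past its limit cannot be read. Still open, going by these compounds, is whether a longer chain, such as phenethyl, or a benzyl group carrying a hydroxyl or an amine, would match or pass compound 1.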